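The compounds below may be only part of what the source reports. "The series", "measured", "known", "first", "only" and "open" are said of these compounds alone.

Measured compounds:
Compound 1 `CCCCCOc1cc(CCc2nc(C)c(CC)s2)nc(NCc2cc(Cl)cc(NC(=O)OC(C)C)c2)c1` gives 35 nM in an assay on cells for binding affinity to Neuropeptide Y receptor type 1 (Homo sapiens); a higher number here means a weaker inhibitor, a lower number a stronger inhibitor.
Compound 2 `CCc1sc(CCc2cc(OCC3(C)CC3)cc(NCc3cc(Cl)cc(NC(=O)OC(C)C)c3)n2)nc1C` gives 17 nM in this assay.
Compound 3 `CCc1sc(CCc2cc(OC3CCCC3)cc(NCc3cc(Cl)cc(NC(=O)OC(C)C)c3)n2)nc1C` gives 11 nM in this assay.

Compound 3 has the lowest number of the three; its nearest neighbour is compound 2, and the two lie within the scatter of each other, while compound 1 lies furthest away. Compound 4 `CCc1sc(CCc2cc(OCc3ccccc3)cc(NCc3cc(Cl)cc(NC(=O)OC(C)C)c3)n2)nc1C` differs from compound 3 by one change: benzyl in place of cyclopentyl on an oxygen on an aromatic ring.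

All three measured steps touch the same position. There were a 2.1-fold lower number from compound 1 to compound 2 (0.31 log units; beyond the scatter), a 3.2-fold lower number from compound 1 to compound 3 (0.50 log units; beyond the scatter) and a 1.5-fold lower number from compound 2 to compound 3 (0.19 log units; within the scatter). None of them introduces a benzyl group, so the data give no direct reading for this change; they only show that the groups tried so far move this assay by modest amounts in this position. Compound 4 is therefore expected to stay close to compound 3, with the step of a 1.4-fold higher number from compound 3 to compound 4 (0.13 log units; within the scatter) estimated to fall within or only slightly beyond the scatter. Compound 4 is estimated at 15 nM, with a range from 5 nM to 50 nM.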

Compound 4, half-maximal inhibitory concentration: 237 nM
For compound 4 the middle estimate is 16-fold (1.20 log units) below the measured one; measured number outside the range, above it.
By their numbers in this assay, from the lowest: compounds 3 and 2 (each within the scatter of the next); then compound 1; then compound 4.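

Benzyl on this oxygen moves the number in this assay much further than any change among the earlier compounds, with a 22-fold higher number from compound 3 to compound 4 (1.33 log units; beyond the scatter), a 14-fold higher number from compound 2 to compound 4 (1.14 log units; beyond the scatter) and a 6.8-fold higher number from compound 1 to compound 4 (0.83 log units; beyond the scatter). The position therefore tolerates less than the earlier steps suggested: pentyl, (1-methylcyclopropyl)methyl and cyclopentyl all give lower numbers than benzyl, the only one of the four groups that carries an aromatic ring, and no compound shown goes against this. Nothing available explains why this change raises the number so sharply.

The compounds shown leave open whether the rise follows the phenyl ring itself or its link to the oxygen. A cyclohexylmethyl, phenethyl or pyridylmethyl group on this oxygen would help separate these readings.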